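Swapping a sulfonyl methyl for amino

The compounds below may be only part of what the source reports. "The series", "measured", "known", "first", "only" and "open" are said of these compounds alone.

Measured so far in an in vitro assay on Sf21 cells for inhibition of high affinity 3',5'-cyclic-AMP phosphodiesterase 7A (Homo sapiens), read by scintillation proximity assay, with a stated time of 30 min; on this read-out lower numbers stand for stronger inhibition and higher numbers for weaker inhibition:
Compound 1, `CNC(=O)c1ccc(NC(=O)c2cn(Cc3c(F)cccc3F)c3ccc(=O)[nH]c3c2=O)cc1`: compound 1 gives 29 nM
Compound 2, `CS(=O)(=O)c1ccc(NC(=O)c2cn(Cc3c(F)cccc3F)c3ccc(=O)[nH]c3c2=O)cc1`: compound 2 gives 27 nM

Compound 2 carries the lowest of these two numbers, but compound 1 sits within the scatter of it, so the two cannot be told apart. Compound 3, `NS(=O)(=O)c1ccc(NC(=O)c2cn(Cc3c(F)cccc3F)c3ccc(=O)[nH]c3c2=O)cc1`, differs from compound 2 by amino in place of methyl on a sulfonyl sulfur. Among the measured compounds shown here, the only measured step, a 1.1-fold lower number from compound 1 to compound 2 (0.03 log units; within the scatter), alters a different group at that place and offers no direct guide for this change. Compound 3 is therefore expected to stay close to that mark, a step of a 1.1-fold lower number from compound 2 to compound 3 (0.03 log units; within the scatter) in this assay. Compound 3 is estimated at 25 nM, between 10 nM and 70 nM.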

Compound 3, half-maximal inhibitory concentration: 34 nM
Compound 3: the middle estimate sits 1.4-fold (0.13 log units) below what was measured; the range from low to high includes it.
By their numbers in this assay, from the lowest: compounds 2, 1 and 3 (each within the scatter of the next).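

In this assay, amino in place of methyl on a sulfonyl sulfur gives a 1.3-fold higher number from compound 2 to compound 3 (0.10 log units; within the scatter) and stays within the scatter, so the hydrogen-bond donor that amino brings makes no measurable difference here. Sulfamoyl in place of methylcarbamoyl on an aromatic carbon gives a 1.2-fold higher number from compound 1 to compound 3 (0.07 log units; within the scatter) and is also within the scatter, so all three groups at this place read alike. Nothing available here explains this likeness. Still open, from the compounds shown here alone, is whether a dimethylamino group on the sulfonyl sulfur or a carboxylic acid on the aromatic carbon would shift the number beyond the scatter.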